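The compounds below may be only part of what the source reports. "The series", "measured", "known", "first", "only" and "open" are said of these compounds alone.

Measured in a functional assay on NCI-H460 cells (Homo sapiens) for cytotoxicity, read by MTT assay, with a stated time of 48 h; on this read-out lower numbers stand for stronger inhibition and higher numbers for weaker inhibition:

- Compound 1 `COc1cc(OC)c(/C=C/C(=O)/C=C/c2cc3ccccc3nc2Oc2ccccc2)c(OC)c1`: > 10000 nM, a limit
- Compound 2 `COc1cc(OC)c(/C=C/C(=O)/C=C/c2cc3ccccc3nc2Oc2ccc(Br)cc2)c(OC)c1`: > 10000 nM, a limit
- Compound 3 `COc1cc(OC)c(OC)cc1/C=C/C(=O)/C=C/c1cc2ccccc2nc1Oc1cccc(Cl)c1`: > 10000 nM, a limit

Compound 3 gives > 10000 nM, which is a limit of the assay and not a number. The same is true across the series, since the data show only (the limit of > 10000 nM in this assay, at which 3 of the 3 values shown sit). Compound 4 `COc1cc(OC)c(/C=C/C(=O)/C=C/c2cc3ccccc3nc2Oc2cccc(Cl)c2)c(OC)c1` has the same atoms as compound 3, joined differently: 2,4,6-trimethoxyphenyl in place of 2,4,5-trimethoxyphenyl on a double-bonded chain carbon bound to a double-bonded chain carbon.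

Going by the values given here, no measured step covers this exact change. Among the compounds with values here, the only step available, a step that the two limits leave unreadable from compound 1 to compound 2, has no readable size, so it offers no guide to how large a change might be. The expectation rests instead on compound 1, which carries the 2,4,6-trimethoxyphenyl group and gives > 10000 nM, a limit. Compound 2 carries the same group and gives > 10000 nM, also a limit.

In this assay, no step beyond the scatter is expected in either direction, and another limit is the likeliest result. The expected step is a step that the limit leaves unreadable from compound 3 to compound 4. The estimated value for compound 4 is 15000 nM, with an expected range from 6000 nM to 40000 nM.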

Compound 4, half-maximal inhibitory concentration: > 10000 nM
Compound 4: no number, only a limit (the forecaster's own chance of this, stated with the estimate: 85%); the middle value does not contradict the limit.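

Compound 4 gives > 10000 nM, which is a limit of the assay and not a number. No step among compound 1, compound 2, compound 3 and compound 4 can be read, since all four sit at one limit: the limit of > 10000 nM in this assay, at which 4 of the 4 values shown sit.

The compounds shown leave open whether the trimethoxyphenyl arrangement or the halogen on the phenoxy ring changes cytotoxicity at all.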